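The source may report more compounds than this note shows. Statements on the series, on what has been measured and on what is new or still open speak of the compounds shown alone.

Measured compounds:
compound 1, `O=C(Nc1cccc(-n2cc(-c3ccncc3)c(-c3cc(O)cc(Cl)c3)n2)c1)Nc1ccc(Cl)c(Cl)c1`, -33.8%;
compound 2, `COc1cc(Cl)cc(-c2nn(-c3cccc(NC(=O)Nc4ccc(Cl)c(Cl)c4)c3)cc2-c2ccncc2)c1`, 13.3%;
compound 3, `O=C(Nc1cccc(-n2cc(-c3ccncc3)c(-c3cc(O)cc(Cl)c3)n2)c1)c1cc(C(F)(F)F)cc(C(F)(F)F)c1`, 61%.

In a functional assay on SW-620 cells (Homo sapiens) for inhibition, read by sulforhodamine B assay, with a stated time of 48 h, tested at 10 uM (on this read-out higher numbers stand for a weaker effect at the one concentration tested and lower numbers for a stronger effect), compound 1 gives -33.8%, the lowest of the three numbers. Compound 2 differs from compound 1 by methyl in place of hydrogen on an oxygen on an aromatic ring, and this change gave a number 47.1 percentage points higher from compound 1 to compound 2 (beyond the scatter). Compound 3 gives 61% in this assay, the highest of the three; its gap to compound 2 lies beyond the scatter, as does its gap to compound 1. How the core of compound 3 differs from the core of compound 1 is not broken down here.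

Compound 4, `COc1cc(Cl)cc(-c2nn(-c3cccc(NC(=O)c4cc(C(F)(F)F)cc(C(F)(F)F)c4)c3)cc2-c2ccncc2)c1`, has not been measured in this assay. It differs from compound 3 by methyl in place of hydrogen on an oxygen on an aromatic ring, the same change as that from compound 1 to compound 2, on the same place.

The expectation for compound 4 rests on the step from compound 1 to compound 2, a number 47.1 percentage points higher from compound 1 to compound 2 (beyond the scatter), which moved the number upward by a large amount. Because compound 3 already starts at 61%, the expected step of a number 29 percentage points higher from compound 3 to compound 4 (beyond the scatter) from compound 3 to compound 4 is taken as somewhat smaller than the earlier one. Compound 4 is therefore estimated to give 90% in this assay, expected to fall between 65% and 110%.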

Compound 4, a percentage reported as activity, at one concentration (the size of the read-out at that concentration, not a potency): 86.2%
Estimate against measurement, compound 4: 3.8 percentage points above; low and high end bracket the measured number.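

In this assay, going from 3-chloro-5-hydroxyphenyl to 3-chloro-5-methoxyphenyl on the core of compound 3 gave a number 25.2 percentage points higher from compound 3 to compound 4 (beyond the scatter), so the number moved upward, towards a weaker effect, just as it did when the same change was made on the core of compound 1. The direction of the change therefore carried from one core to the other, but its size did not: the same change on two cores in this assay, a number 47.1 percentage points higher (beyond the scatter) from compound 1 to compound 2 and a number 25.2 percentage points higher (beyond the scatter) from compound 3 to compound 4, 21.9 percentage points apart, beyond the scatter of two such steps

Among these compounds, with only two matched pairs, this shows that the size of the step depends on the core in these compounds, but it does not show which part of the two cores accounts for the gap, nor does it give a rule for predicting the step on any further core.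

From the compounds shown here alone, what an ethyl group or a longer chain on that oxygen would do in this assay stays open, as does the effect of an amine or a carboxylic acid in place of the hydroxy group. Going by these compounds, it also remains open whether the same upward direction and the same dependence on the core would appear across a range of concentrations, since each of these numbers comes from a single tested concentration.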